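Working notes: compound 2 to compound 3 in cytotoxicity

This account rests on a few compounds, and the source may have more. Where it says the series, first, only, none or still open, it means among the compounds named here.

Compound 1 `CC1(C)CCN(S(=O)(=O)c2ccc(NC(=O)c3ccc([N+](=O)[O-])o3)cc2)CC1` and compound 2 `N=C1CCN(S(=O)(=O)c2ccc(NC(=O)c3ccc([N+](=O)[O-])o3)cc2)CC1` share one core and differ only in the group on the sulfonyl sulfur. In an ADME assay on IMR-90 cells (Homo sapiens) for cytotoxicity, read by CellTiter-Blue, with a stated time of 46 h (a lower number here means that less compound is needed, a higher number that more compound is needed for the effect), compound 1 reaches only a limit of the assay, > 25000 nM. In this assay compound 2 likewise stands at a limit, > 25000 nM, so no number is in hand for it. The step that the two limits leave unreadable from compound 1 to compound 2 is consequently not readable. All that the measurements give is the limit of > 25000 nM in this assay, at which 2 of the 2 values shown sit.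

Compound 3 `O=C(Nc1ccc(S(=O)(=O)C2CCCCC2)cc1)c1ccc([N+](=O)[O-])o1` is the next candidate. The change cyclohexyl in place of 4-iminopiperidin-1-yl on a sulfonyl sulfur again falls on the sulfonyl sulfur. Going by the values given here, the one measured step touches the same position but carries no readable size, so nothing fixes a direction or magnitude for this change. Given two measurements at the limit, compound 3 is expected to come out near that limit as well. The step of a number no higher from compound 2 to compound 3 (the limit leaves the size open) is expected to stay within scatter if a number appears. For compound 3 the estimate is 25000 nM, with a range from 8000 nM to 60000 nM.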

Compound 3, half-maximal effective concentration: > 25000 nM
Compound 3 gave a limit, no number; the forecaster's own chance of this, stated with the estimate: 75%; the middle value lies on the limit itself.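

In this assay, going by these compounds alone, compound 3 gives only a limit, > 25000 nM, so no step among compound 1, compound 2 and compound 3 can be read. The compounds shown leave open how cyclohexyl, 4-iminopiperidin-1-yl and 4,4-dimethylpiperidin-1-yl on a sulfonyl sulfur compare in cytotoxicity: the limit of > 25000 nM in this assay, at which 3 of the 3 values shown sit.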